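Bromo for fluoro on the benzyl ring of compound 2

A few compounds are considered here, and "the series" means these few. Any claim that something is new, unique, unknown or untested is made for them only; others in the source may bear on it.

Measured so far:
Compound 1 `COc1cccc(Cc2cc(-c3ccccc3)nn(CC(=O)Nc3ccc(Br)cc3)c2=O)c1`: > 50000 nM
Compound 2 `Cc1cc(Cc2cccc(F)c2)c(=O)n(CC(=O)Nc2ccc(Br)cc2)n1`: > 50000 nM

In an assay on HL-60 cells for agonist activity at N-formyl peptide receptor 3 (Homo sapiens), read by calcium flux (a higher number here means that more compound is needed for the effect, a lower number that less compound is needed), compound 1 gives no number, only a limit, > 50000 nM. Compound 2 likewise gives only a limit in this assay, > 50000 nM. Among the compounds with values here, both entries therefore sit at the limit of > 50000 nM in this assay, at which 2 of the 2 values shown sit, so compound 2 stands level with compound 1 at the assay ceiling and no measured step exists that could size the effect of any change.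

Compound 3 `Cc1cc(Cc2cccc(Br)c2)c(=O)n(CC(=O)Nc2ccc(Br)cc2)n1` differs from compound 2 by bromo in place of fluoro on an aromatic carbon. Within the data shown here, nothing among the measured compounds gives this change a direction. The step from compound 2 to compound 3 is expected to be none beyond the scatter, a number no higher from compound 2 to compound 3 (the limit leaves the size open). Compound 3 is accordingly expected near 50000 nM, in the range 15000 nM to 100000 nM, and most probably to be reported again as a limit rather than a number.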

Compound 3, half-maximal effective concentration: > 50000 nM
Compound 3 ended at the assay's limit (the forecaster's own chance of this, stated with the estimate: 80%); the middle value lies on the limit itself.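

In this assay compound 2 and compound 3 both give only a limit, not a number, so no step can be read for bromo in place of fluoro. From the compounds shown here alone, whether any compound of this series gives a measurable value, and how far any change would shift it, stays open.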